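Three limits, then compound 4

The source may report more compounds than this note shows. Statements on the series, on what has been measured and on what is new or still open speak of the compounds shown alone.

Values in a functional assay on HeLa cells (Homo sapiens) for inhibition, read by MTT assay, with a stated time of 48 h; a higher number here means a weaker inhibitor, a lower number a stronger inhibitor
Compound 1 `COc1ccc(CNC(=O)/C=C/c2coc3cc(O)ccc3c2=O)cc1` gives > 100000 nM (a limit)
Compound 2 `O=C(/C=C/c1coc2cc(O)ccc2c1=O)NCc1ccccc1` gives > 100000 nM (a limit)
Compound 3 `COc1ccc2c(=O)c(/C=C/C(=O)Nc3ccccc3)coc2c1` gives > 100000 nM (a limit)

Compound 3 has no exact number, only its limit of > 100000 nM. The evidence so far is the limit of > 100000 nM in this assay, at which 3 of the 3 values shown sit. Compound 4 `COc1ccc2c(=O)c(/C=C/C(=O)NCc3cccc(F)c3)coc2c1` is still unmeasured. It carries 3-fluorobenzyl in place of phenyl on an amide-type nitrogen. Among the compounds with values here, the one measured step, a step that the two limits leave unreadable from compound 1 to compound 2, is a different change, hydrogen in place of methoxy on an aromatic carbon, and gives no size to carry over. No shift in either direction is therefore expected in this assay, and the expected change is a number no higher from compound 3 to compound 4 (the limit leaves the size open). The estimate for compound 4 is 100000 nM, with an expected range from 30000 nM to 300000 nM.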

Compound 4, half-maximal inhibitory concentration: 17600 nM
For compound 4 the middle estimate is 5.7-fold (0.75 log units) above the measured one; the measured number lies below the stated range.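

In this assay, within the data shown here, 3-fluorobenzyl in place of phenyl on the amide-type nitrogen gives an at least 5.6-fold lower number from compound 3 to compound 4 (0.75 log units; beyond the scatter) and so shows that this position can move the number, which the earlier compounds, all stuck at a limit, could not show. From the compounds shown here alone, the true size of the step stays open because compound 3 has only a limit: the limit of > 100000 nM in this assay, at which 3 of the 4 values shown sit.

The carbon link and the fluorine enter together, so their shares cannot be told apart. Going by these compounds, whether a longer chain such as 2-phenylethyl, or an amine or carboxylic acid on the ring in place of fluorine, would change the number also stays open.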